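This account rests on a few compounds, and the source may have more. Where it says the series, first, only, none or still open, it means among the compounds named here.

Compound 3 `CC(C)S(=O)(=O)N1CCc2nc(C#Cc3ccccc3)sc2C1` stands at the upper limit of an assay on HEK293 cells for positive allosteric modulation of metabotropic glutamate receptor 5 (Homo sapiens), read by FLIPR, with a stated time of 1 h; on this read-out lower numbers stand for an effect already at smaller amounts and higher numbers for an effect only at larger amounts of compound: the value recorded for compound 3 is > 10000 nM, a limit rather than a number. Compound 1 `CCN1CCc2nc(C#Cc3ccccc3)sc2C1` likewise gives only a limit, > 10000 nM. Compound 2 `O=C(C1CCC1)N1CCc2nc(C#Cc3ccccc3)sc2C1` also gives only a limit, > 10000 nM. The three measured steps, a step that the two limits leave unreadable from compound 1 to compound 2, a step that the two limits leave unreadable from compound 1 to compound 3 and a step that the two limits leave unreadable from compound 2 to compound 3, all alter the group on the ring nitrogen and none can be read, since (the limit of > 10000 nM in this assay, at which 3 of the 3 values shown sit). Compound 4 `O=S(=O)(C1CCCCC1)N1CCc2nc(C#Cc3ccccc3)sc2C1` differs from compound 3 by cyclohexyl in place of isopropyl on a sulfonyl sulfur. Going by the values given here, no measured step touches the sulfonyl substituent, so the three unreadable steps give no direction for this change. The step expected in this assay is a number no higher from compound 3 to compound 4 (the limit leaves the size open). Compound 4 is therefore estimated at 10000 nM in this assay, with a range from 3000 nM to 30000 nM, most likely again a limit.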

Compound 4, half-maximal effective concentration: > 10000 nM
Compound 4 ended at the assay's limit; the forecaster's own chance of this, stated with the estimate: 80%; the middle value sits exactly at the limit.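

No step can be read from compound 3 to compound 4, because both sit at the same limit: the limit of > 10000 nM in this assay, at which 4 of the 4 values shown sit. The compounds shown leave open whether cyclohexyl and isopropyl on a sulfonyl sulfur differ at all.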